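A Benzyl Group Enters at the Ring Nitrogen

The compounds below may be only part of what the source reports. "The series", "measured", "known", "first", "only" and "open" are said of these compounds alone.

Compound 1 `CCCn1c(=O)[nH]c2nc(-c3ccc(S(=O)(=O)N4CCN(c5cccc(Br)c5)CC4)cc3)[nH]c2c1=O` and compound 2 `CCCn1c(=O)[nH]c2nc(-c3ccc(S(=O)(=O)N4CCN(c5ccc(C)cc5)CC4)cc3)[nH]c2c1=O` share one core and differ only in the group on an amine nitrogen in a ring. In an assay on CHO cells for displacement of a labelled ligand from adenosine receptor A2b (Homo sapiens), read by scintillation counting, with a stated time of 75 min, in the presence of a further agent that is not named here (on this read-out higher numbers stand for weaker inhibition and lower numbers for stronger inhibition), compound 1 gives 0.234 nM, and compound 2 gives 0.706 nM; the step of a 3.0-fold higher number from compound 1 to compound 2 (0.48 log units; beyond the scatter) is modest. Among the compounds with values here, compound 2 thus holds the higher of the two numbers, with compound 1 as its only neighbour. Compound 3 `CCCn1c(=O)[nH]c2nc(-c3ccc(S(=O)(=O)N4CCN(Cc5ccc(Br)cc5)CC4)cc3)[nH]c2c1=O` carries the change (4-bromobenzyl in place of 4-methylphenyl on an amine nitrogen in a ring). Within the data shown here, the single measured step bears on it only in part: it shows that exchanging the group on this nitrogen moves this assay by a modest amount, but no measured pair covers a benzyl group, so the direction stays open. A step of modest size in either direction, or none beyond the scatter, is expected. Compound 3 is estimated at 0.5 nM, within 0.12 nM to 2 nM. The expected step is a 1.4-fold lower number from compound 2 to compound 3 (0.15 log units; within the scatter).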

Compound 3, inhibition constant: 0.153 nM
Beside the measured number, compound 3's estimate is 3.3-fold (0.51 log units) above it, and the stated range covers the measured number.
By their numbers in this assay, from the lowest: compounds 3 and 1 (each within the scatter of the next); then compound 2.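

In this assay, within the data shown here, the first measured step to a benzyl group on this amine nitrogen in a ring gives a direction: 4-bromobenzyl in place of 4-methylphenyl gives a 4.6-fold lower number from compound 2 to compound 3 (0.66 log units; beyond the scatter) and is modest in size. Against 3-bromophenyl, the same group gives a 1.5-fold lower number from compound 1 to compound 3 (0.18 log units; within the scatter), so the two bromine-bearing groups cannot be told apart here, although one is a benzyl group and the other a phenyl group. Nothing measured here gives a reason for these steps.

Since 4-bromobenzyl differs from 4-methylphenyl in both the added carbon and the bromine, the shown compounds do not separate the two contributions. An unsubstituted benzyl, a 4-methylbenzyl, a longer chain such as 2-phenylethyl or a benzoyl group on this nitrogen would each bear on that question.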